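Anilino aryl change on the shared core

The source may report more compounds than this note shows. Statements on the series, on what has been measured and on what is new or still open speak of the compounds shown alone.

Compound 1 `COc1ccc(Nc2ccc3c(c2)C(O)(Cc2ccccc2)C(=O)N3)cc1` in a functional assay on A549 cells (Homo sapiens) for antiproliferative activity, read by MTT assay, with a stated time of 48 h; a higher number here means a weaker inhibitor, a lower number a stronger inhibitor: > 30000 nM, a limit of the assay.
Compound 2 `CCCCCC1(O)C(=O)Nc2ccc(Nc3ccc(C)cc3)cc21` in this assay: 8100 nM.
Compound 3 `Cc1ccc(Nc2ccc3c(c2)C(O)(Cc2ccccc2)C(=O)N3)cc1` in this assay: 4100 nM.

Compound 3 holds the lowest of the two numbers; its nearest neighbour is compound 2, at a 2.0-fold lower number from compound 2 to compound 3 (0.30 log units; within the scatter), which is within the scatter, so no order between the two is claimed. Compound 1 stands only as a limit (the limit of > 30000 nM in this assay, at which 1 of the 3 values shown sits).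

Compound 4 `O=C1Nc2ccc(Nc3ccccc3Cl)cc2C1(O)Cc1ccccc1` differs from compound 3 in one place: 2-chlorophenyl in place of 4-methylphenyl on a nitrogen on an aromatic ring. Of the measured steps, an at least 7.3-fold lower number from compound 1 to compound 3 (0.86 log units; beyond the scatter) bears directly on this change, as it also alters the aryl group on the same nitrogen; that step was at least modest. The step of a 2.0-fold lower number from compound 2 to compound 3 (0.30 log units; within the scatter) concerns a different site and shows only a change within the scatter there. The one relevant step shows that the aryl group can shift the number substantially, but in which direction 2-chlorophenyl acts is not shown. Compound 4 is therefore expected near compound 3, with a wide range. The expected step is a 1.5-fold higher number from compound 3 to compound 4 (0.17 log units; within the scatter). Compound 4 is estimated at 6000 nM, range 2000 nM to 25000 nM.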

Compound 4, half-maximal inhibitory concentration: 2300 nM
Compound 4: middle estimate off by 2.6-fold (0.42 log units), on the high side; low and high end bracket the measured number.
By their numbers in this assay, from the lowest: compounds 4, 3 and 2 (each within the scatter of the next, the first and the last beyond it). At a limit, above all of these: compound 1.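

In this assay, 2-chlorophenyl in place of 4-methylphenyl on the nitrogen gives a 1.8-fold lower number from compound 3 to compound 4 (0.25 log units; within the scatter), so these two aryl groups are not told apart at this position and no order between them is claimed. The earlier compounds shown here showed one aryl change that mattered here; a second change away from 4-methoxyphenyl now gives an at least 13-fold lower number from compound 1 to compound 4 (1.11 log units; beyond the scatter), so 4-methoxyphenyl stands apart from both of the other aryl groups. The figure for compound 1 is a limit, not a number: the limit of > 30000 nM in this assay, at which 1 of the 4 values shown sits.

Still open, going by these compounds, is whether the group itself or its place on the ring counts, which 4-chlorophenyl or 2-methylphenyl on the same nitrogen would separate. Also open, on these data alone, is how this position responds to an aryl ring carrying an amine or a carboxylic acid.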